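Replacing the aryl tail of compound 2 with a short alkyne

The source may hold more compounds than are shown below. What is called first, only, known or untested is meant among the compounds shown, and "the series" means these compounds.

Two compounds of this series have numbers in a functional assay on 1321-N1 cells for agonist activity at P2Y purinoceptor 2 (Homo sapiens), read by scintillation counting and inositol phosphate accumulation; on this read-out higher numbers stand for an effect only at larger amounts of compound and lower numbers for an effect already at smaller amounts. Compound 1 `O=c1[nH]/c(=N\OCCCc2ccc(I)cc2)ccn1[C@@H]1O[C@H](COP(=O)(O)OP(=O)(O)OP(=O)(O)O)[C@@H](O)[C@H]1O` gives 187 nM. For the measured compounds named here, compound 2 `O=c1[nH]/c(=N\OCCCc2ccc([N+](=O)[O-])cc2)ccn1[C@@H]1O[C@H](COP(=O)(O)OP(=O)(O)OP(=O)(O)O)[C@@H](O)[C@H]1O` gives 458 nM, the highest of the two numbers; the only measured step, a 2.4-fold higher number from compound 1 to compound 2 (0.39 log units; beyond the scatter), is a modest change at the aromatic ring of the tail. Compound 3 `C#CCCCO/N=c1/ccn([C@@H]2O[C@H](COP(=O)(O)OP(=O)(O)OP(=O)(O)O)[C@@H](O)[C@H]2O)c(=O)[nH]1` is not yet measured; it differs from compound 2 by ethynyl in place of 4-nitrophenyl on a saturated chain carbon, three bonds along the chain from an oxygen. Going by the values given here, no measured step bears directly on this change: the step from compound 1 to compound 2 swaps one substituent on the aromatic ring, whereas here the whole ring together with its nitro group is removed and a small alkyne is left in its place. Among the compounds with values here, with no comparable precedent, a step of moderate size in either direction cannot be excluded, and a somewhat higher number is expected for compound 3 in this assay, a 1.5-fold higher number from compound 2 to compound 3 (0.18 log units; within the scatter). The estimate for compound 3 is 700 nM, with a range from 150 nM to 3000 nM.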

Compound 3, half-maximal effective concentration: 168 nM
The estimate for compound 3 lay 4.2-fold (0.62 log units) above the measured number; low and high end bracket the measured number.
By their numbers in this assay, from the lowest: compounds 3 and 1 (each within the scatter of the next); then compound 2.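

In this assay, the aromatic ring is not needed at this position for the lower numbers seen in these compounds: ethynyl in place of 4-nitrophenyl on a saturated chain carbon, three bonds along the chain from an oxygen, gives a 2.7-fold lower number from compound 2 to compound 3 (0.44 log units; beyond the scatter). The same exchange starting from 4-iodophenyl gives a 1.1-fold lower number from compound 1 to compound 3 (0.05 log units; within the scatter), so the small ethynyl and the much larger 4-iodophenyl cannot be told apart here, and only 4-nitrophenyl stands off from both. The data on hand offer no explanation for this.

From the compounds shown here alone, it remains open whether the triple bond matters or any short tail would serve, a question that a plain pentyl chain in place of pent-4-yn-1-yl would address. Also open, going by these compounds, is whether an unsubstituted phenyl would fall with 4-iodophenyl or with 4-nitrophenyl.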